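Swapping a hydroxy for an amide chain on a benzimidazole

A few compounds are considered here, and "the series" means these few. Any claim that something is new, unique, unknown or untested is made for them only; others in the source may bear on it.

Measured compounds:
- compound 1, `COc1ccc(-c2nc3cc(C(F)(F)F)ccc3[nH]2)c(OC)c1OC`, 93000 nM
- compound 2, `Oc1ccc(-c2nc3cc(C(F)(F)F)ccc3[nH]2)cc1`, 17000 nM
- compound 3, `CN1CCN(CC(=O)Nc2ccc(-c3nc4cc(Cl)c(Cl)cc4[nH]3)cc2)CC1`, 11000 nM

The three compounds share a core in which a six-membered aromatic ring of carbon only is attached to a benzimidazole that carries either a trifluoromethyl group or two chlorines. In an ADME assay on MT4 cells (Homo sapiens) for cytotoxicity, read by MTT assay, with a stated time of 96 h (a lower number here means that less compound is tolerated, a higher number that more compound is tolerated), compound 1 gives 93000 nM and tolerates the most compound. Compound 2 stands second highest of the three numbers: its gap to compound 3 lies within the scatter, while its gap to compound 1 lies beyond it, so compound 1 is the only one that clearly differs.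

The next compound, compound 4, `CCN(CC)CC(=O)Nc1ccc(-c2nc3cc(C(F)(F)F)ccc3[nH]2)cc1`, has not yet been measured. It differs from compound 2 by (((diethylamino)methyl)carbonyl)amino in place of hydroxy on an aromatic carbon. Compound 3 already carries a related amide chain on the same ring, although with a different group at its end and a different pair of substituents on the benzimidazole, and its number sits close to that of compound 2. On that basis the change is expected to bring a step of a 1.4-fold lower number from compound 2 to compound 4 (0.15 log units; within the scatter) that stays within the scatter, with no direction claimed. Compound 4 is therefore estimated at 12000 nM, within a range from 4000 nM to 40000 nM.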

Compound 4, half-maximal cytotoxic concentration: 8000 nM
Estimate against measurement, compound 4: 1.5-fold (0.18 log units) above; low and high end bracket the measured number.
By their numbers in this assay, from the lowest: compounds 4, 3 and 2 (each within the scatter of the next, the first and the last beyond it); then compound 1.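

Among the compounds shown here, at the aromatic carbon para to a large group, this is the first change that can be read on its own, since the earlier compounds differ from each other in more than one place. In this assay, putting (((diethylamino)methyl)carbonyl)amino in place of hydroxy brings a 2.1-fold lower number from compound 2 to compound 4 (0.33 log units; beyond the scatter), a modest step that lies beyond the usual scatter and means that less compound is tolerated with the longer chain at this position. Nothing in the data shown explains why the number moves with this change.

The step swaps one heavy atom for nine, so the compounds shown leave open whether the number follows the amide link, the diethylamino end or simply the longer chain. A plain acetylamino group or a simple amine at the same position would help separate these parts, while a piperidine or a carboxylic acid at the end of the chain would show whether the diethylamino group itself matters.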